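Amide-Substituent Exchange on the Shared Core: Compound 4

A few compounds are considered here, and "the series" means these few. Any claim that something is new, unique, unknown or untested is made for them only; others in the source may bear on it.

Measured so far in a functional assay on A549 cells (Homo sapiens) for cytotoxicity, read by MTT assay, with a stated time of 72 h; a higher number here means a weaker inhibitor, a lower number a stronger inhibitor:
compound 1 `COc1cc2c(Oc3ccc(NC(=O)c4cn(-c5ccccc5OC)cn4)cc3F)ccnc2cc1OCCCN1CCN(C)CC1` gives 70 nM
compound 2 `COc1cc2c(Oc3ccc(NC(=O)c4cn(-c5ccc(Cl)cc5)cn4)cc3F)ccnc2cc1OCCCN1CCN(C)CC1` gives 5200 nM
compound 3 `COc1cc2c(Oc3ccc(NC(=O)c4cn(-c5ccc(Cl)cc5)cn4)cc3F)ccnc2cc1OCCCN1CCCCC1` gives 6560 nM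

Compound 2 stands second highest of the three numbers in this assay. The nearest number lies within the scatter: a 1.3-fold higher number from compound 2 to compound 3 (0.10 log units; within the scatter). The furthest is a large step: a 74-fold higher number from compound 1 to compound 2 (1.87 log units; beyond the scatter).

Compound 4 `COc1cc2c(Oc3ccc(NC(=O)/C=C/S(=O)(=O)c4ccccc4F)cc3F)ccnc2cc1OCCCN1CCN(C)CC1` differs from compound 2 by 2-((2-fluorophenyl)sulfonyl)ethenyl in place of 1-(4-chlorophenyl)-1H-imidazol-4-yl on a carbonyl carbon. Among the measured compounds shown here, no measured step covers this exchange. For the measured compounds named here, the only step at the carbonyl carbon, a 74-fold higher number from compound 1 to compound 2 (1.87 log units; beyond the scatter), shows that a change of the group there can move the number far; the step of a 1.3-fold higher number from compound 2 to compound 3 (0.10 log units; within the scatter) concerns another part of the molecule and is within the scatter. The direction cannot be read from these steps, so a step of uncertain direction is expected, a 3.5-fold lower number from compound 2 to compound 4 (0.54 log units; beyond the scatter). Compound 4 is estimated at 1500 nM, with a range from 150 nM to 12000 nM.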

Compound 4, half-maximal inhibitory concentration: 150 nM
Beside the measured number, compound 4's estimate is 10-fold (1.00 log units) above it; the range from low to high includes it.
By their numbers in this assay, from the lowest: compound 1; then compound 4; then compounds 2 and 3 (each within the scatter of the next).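

At the carbonyl carbon, 2-((2-fluorophenyl)sulfonyl)ethenyl in place of 1-(4-chlorophenyl)-1H-imidazol-4-yl gives a 35-fold lower number from compound 2 to compound 4 (1.54 log units; beyond the scatter) in this assay. Among the compounds shown here, the number at this position can therefore fall sharply with the five-membered aromatic ring gone, whereas the earlier compounds all kept that ring. Nothing available accounts for this step.

Still open, on these data alone, is whether a saturated ethyl chain in place of the ethenyl keeps the lower number. Also open, as far as these compounds go, is how an amine on the fluorophenyl ring would change it.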